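The source may hold more compounds than are shown below. What is called first, only, known or untested is meant among the compounds shown, and "the series" means these compounds.

Working notes on the series. The shared core of compound 3 `CC(=O)Nc1ccc(-c2nc3cc(C(F)(F)F)ccc3[nH]2)cc1` carries an acetamido group; in an ADME assay on Vero cells (Chlorocebus sabaeus) for cytotoxicity (a lower number here means that less compound is tolerated, a higher number that more compound is tolerated), compound 3 gives 50000 nM. Among the numbers given, compound 3 sits highest; its nearest neighbour is compound 1 `O=C(CN1CCCCC1)Nc1ccc(-c2nc3cc(C(F)(F)F)ccc3[nH]2)cc1`, which in this assay gives 31000 nM, and the step of a 1.6-fold higher number from compound 1 to compound 3 (0.21 log units; within the scatter) lies within the scatter, so the two are not ordered. Compound 2 `O=C(CN1CCCC1)Nc1ccc(-c2nc3cc(C(F)(F)F)ccc3[nH]2)cc1` returns only a limit, > 100000 nM, in this assay; it sits at the limit of > 100000 nM in this assay, at which 1 of the 3 values shown sits.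

The next compound, compound 4 `O=C(O)CCC(=O)Nc1ccc(-c2nc3cc(C(F)(F)F)ccc3[nH]2)cc1`, differs from compound 3 by carboxymethyl in place of hydrogen on a saturated chain carbon bound to a carbonyl carbon. Within the data shown here, the measured steps at the same place are a 1.6-fold higher number from compound 1 to compound 3 (0.21 log units; within the scatter) and an at least 2.0-fold lower number from compound 2 to compound 3 (0.30 log units; that floor lies within the scatter), both within the scatter, and the only step beyond it, an at least 3.2-fold higher number from compound 1 to compound 2 (0.50 log units; beyond the scatter), exchanges two cyclic amines rather than introducing a carboxymethyl group. Among the measured compounds shown here, no measured step covers an acid at this position, so the expectation rests on the two changes at the same carbon, which barely moved the number.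

For compound 4 a step of a 1.3-fold higher number from compound 3 to compound 4 (0.11 log units; within the scatter) in this assay is expected, that is, none beyond the scatter. Compound 4 is therefore estimated at 65000 nM, with a range from 30000 nM to 150000 nM.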

Compound 4, half-maximal cytotoxic concentration: > 100000 nM
Compound 4: only a limit was reported (the forecaster's own chance of this, stated with the estimate: 40%); at least 1.5-fold (0.18 log units) between middle value and limit.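

In this assay compound 4 returns a limit rather than a number, as compound 2 does: the limit of > 100000 nM in this assay, at which 2 of the 4 values shown sit.

A carboxymethyl group in place of piperidin-1-yl on this saturated chain carbon gives an at least 3.2-fold higher number from compound 1 to compound 4 (0.50 log units; beyond the scatter), so a group other than a cyclic amine now also yields a step beyond the scatter at this place, a result the earlier exchange of pyrrolidin-1-yl for piperidin-1-yl could not show. Against hydrogen, the change gives an at least 2.0-fold higher number from compound 3 to compound 4 (0.30 log units; that floor lies within the scatter), and because that floor lies within the scatter, compound 3 and compound 4 cannot yet be ordered; the step between compound 2 and compound 4 cannot be read, since both values are limits.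

As far as these compounds go, how far compound 2 and compound 4 lie past the limit stays open, so the two groups cannot be ranked in this assay's terms. The compounds shown also do not separate the carboxylic acid from the longer chain that carries it, a question that a plain ethyl group or a methyl ester at the same carbon would address.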